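Three saturated amides at the limit, then a methylpyridine

This account rests on a few compounds, and the source may have more. Where it says the series, first, only, none or still open, it means among the compounds named here.

Compound 1 `O=C(C1CC12CCC2)N1CCc2nc(C#Cc3ccccc3)sc2C1` gives > 10000 nM in an assay on HEK293 cells for negative allosteric modulation of metabotropic glutamate receptor 5 (Homo sapiens), read by FLIPR, with a stated time of 1 h (a higher number here means a weaker inhibitor, a lower number a stronger inhibitor), which is a limit of the assay rather than a number. Compound 2 `COC1CC(C(=O)N2CCc3nc(C#Cc4ccccc4)sc3C2)C1` gives > 10000 nM in this assay, again only a limit. Compound 3 `O=C(C1CCOCC1)N1CCc2nc(C#Cc3ccccc3)sc2C1` gives > 10000 nM in this assay, also a limit.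

Compound 3 therefore stands where every measured compound stands, at the limit of > 10000 nM in this assay, at which 3 of the 3 values shown sit. The steps a step that the two limits leave unreadable from compound 1 to compound 2, a step that the two limits leave unreadable from compound 1 to compound 3 and a step that the two limits leave unreadable from compound 2 to compound 3 swap one saturated ring for another, and none can be read in size. Compound 4 `Cc1cccc(C(=O)N2CCc3nc(C#Cc4ccccc4)sc3C2)n1` differs from compound 3 by 6-methylpyridin-2-yl in place of oxan-4-yl on a carbonyl carbon. Going by the values given here, no measured step replaces a saturated ring with an aromatic one, so the measured steps give no direction for this change. Compound 4 is expected to give a readable number, the step of an at least 3.3-fold lower number from compound 3 to compound 4 (0.52 log units; beyond the scatter) being an estimated gain of uncertain size. Compound 4 is estimated at 3000 nM, within 300 nM to 30000 nM.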

Compound 4, half-maximal inhibitory concentration: > 10000 nM
Compound 4 was reported as a limit (the forecaster's own chance of this, stated with the estimate: 50%); at least 3.3-fold (0.52 log units) between middle value and limit.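

Compound 4 also gives only a limit, so its steps from compound 1, compound 2 and compound 3 cannot be read in size: the limit of > 10000 nM in this assay, at which 4 of the 4 values shown sit. Which group on the carbonyl carbon would give a readable number in this assay stays open.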